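The source may hold more compounds than are shown below. What is called first, only, known or untested is meant among the compounds shown, and "the series" means these compounds.

Working notes on the series. Of the compounds shown here, two have numbers so far in a functional assay (aorta) with Rattus norvegicus as the target; on this read-out lower numbers stand for stronger inhibition and higher numbers for weaker inhibition. Compound 1 `CC1(C)Oc2ccc(C#N)cc2[C@@H](/N=C(\NC#N)Nc2cccc(Cl)c2)[C@@H]1O` gives 600 nM. Compound 2 `COC(=O)c1ccc(N/C(=N/[C@@H]2c3cc(C#N)ccc3OC(C)(C)[C@H]2O)NC#N)cc1` gives 18400 nM, the highest of the two numbers, reached by the step of a 31-fold higher number from compound 1 to compound 2 (1.49 log units; beyond the scatter). Compound 3 `CC1(C)Oc2ccc(C#N)cc2[C@@H](/N=C(\NC#N)Nc2ccc3c(c2)CCC3)[C@@H]1O` is not yet measured; it differs from compound 2 as 2,3-dihydro-1H-inden-5-yl in place of 4-(methoxycarbonyl)phenyl on an amine nitrogen. Among the measured compounds shown here, only one measured step bears on this change: the move from 3-chlorophenyl to 4-(methoxycarbonyl)phenyl on the amine nitrogen, which gave a 31-fold higher number from compound 1 to compound 2 (1.49 log units; beyond the scatter). Compound 3 again carries a group without a methoxycarbonyl on that nitrogen, so the number is expected to fall back toward compound 1, though the 2,3-dihydro-1H-inden-5-yl group is new to the series and the extent is uncertain. For compound 3 a step of a 15-fold lower number from compound 2 to compound 3 (1.19 log units; beyond the scatter) is therefore expected in this assay. Compound 3 is estimated at 1200 nM, with a range from 300 nM to 5000 nM.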

Compound 3, half-maximal inhibitory concentration: 41300 nM
Compound 3: the middle estimate sits 34-fold (1.54 log units) below what was measured; the measured number lies above the stated range.
By their numbers in this assay, from the lowest: compound 1; then compound 2; then compound 3.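

In this assay, losing the methoxycarbonyl does not by itself restore a low number: the all-carbon 2,3-dihydro-1H-inden-5-yl gives a 2.2-fold higher number from compound 2 to compound 3 (0.35 log units; beyond the scatter), so the ester-bearing group is not the sole source of the loss at this amine nitrogen. Set against the 3-chlorophenyl group, the same change gives a 69-fold higher number from compound 1 to compound 3 (1.84 log units; beyond the scatter), leaving compound 1 with the lowest number of the three and both other groups far behind it. Nothing available explains this order.

The three compounds leave open whether the low number of compound 1 depends on the chlorine itself, which a plain phenyl or a 3-bromophenyl on the same nitrogen would test. They also leave open whether any other group at this position can reach or pass compound 1.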